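From 4-fluorophenyl to 2-fluorophenyl on a ring nitrogen

This account rests on a few compounds, and the source may have more. Where it says the series, first, only, none or still open, it means among the compounds named here.

In a functional assay on A549 cells (Homo sapiens) for antiproliferative activity, read by MTT assay, with a stated time of 72 h (on this read-out higher numbers stand for weaker inhibition and lower numbers for stronger inhibition), compound 2 (`Nc1nc(N)c2cc(CSC(=S)N3CCN(c4ccc(F)cc4)CC3)ccc2n1`) gives 2040 nM, and compound 1 (`Cc1ccccc1N1CCN(C(=S)SCc2ccc3nc(N)nc(N)c3c2)CC1`) gives 3920 nM, so the two values lie within the scatter of each other. Compound 3 (`Nc1nc(N)c2cc(CSC(=S)N3CCN(c4ccccc4F)CC3)ccc2n1`) differs from compound 2 by 2-fluorophenyl in place of 4-fluorophenyl on an amine nitrogen in a ring, with 2-fluorophenyl in place of 4-fluorophenyl on an amine nitrogen in a ring. Going by the values given here, only one measured step bears on this change. It falls on the same ring nitrogen, where 4-fluorophenyl replaces 2-methylphenyl, and it amounts to a 1.9-fold lower number from compound 1 to compound 2 (0.28 log units; within the scatter). Among the compounds with values here, that single step offers no sign that the group on this nitrogen moves the number in this assay, although no measured compound yet shows a fluorine moved around the phenyl ring. No shift beyond the scatter is therefore expected, and the estimated step is a 1.3-fold higher number from compound 2 to compound 3 (0.11 log units; within the scatter). Compound 3 is expected at about 2600 nM, within an estimated range of 1200 nM to 5600 nM.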

Compound 3, half-maximal inhibitory concentration: 6460 nM
Beside the measured number, compound 3's estimate is 2.5-fold (0.40 log units) below it; the whole stated range lies below it.
By their numbers in this assay, from the lowest: compounds 2, 1 and 3 (each within the scatter of the next, the first and the last beyond it).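

In this assay, going by these compounds alone, 2-fluorophenyl in place of 4-fluorophenyl on the ring nitrogen gives a 3.2-fold higher number from compound 2 to compound 3 (0.50 log units; beyond the scatter), the first step at this position that lies beyond the scatter. The place of the fluorine on the phenyl ring therefore matters in this assay, even though the two groups hold the same atoms. Fluoro in place of methyl on an aromatic carbon gives a 1.6-fold higher number from compound 1 to compound 3 (0.22 log units; within the scatter), so that exchange at the same ring position does not separate the two compounds, and no evidence at hand explains the shift seen with the moved fluorine.

On these data alone, it remains open whether a 3-fluorophenyl group or a plain phenyl group on this ring nitrogen would give a number closer to that of compound 2 or compound 3. Also open, as far as these compounds go, is whether a 2-chlorophenyl or 2-methoxyphenyl group would track with compound 3.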